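Changing the ring on the carbonyl carbon of compound 3

This account rests on a few compounds, and the source may have more. Where it says the series, first, only, none or still open, it means among the compounds named here.

In a functional assay on MV4-11 cells (Homo sapiens) for inhibition, read by luminescence, with a stated time of 3 days (on this read-out lower numbers stand for stronger inhibition of growth and higher numbers for weaker inhibition of growth), compound 3 (`CC[C@@H]1CC[C@@H](C(=O)N2CCOCC2)N1C(=O)C1=C(C(C)C)N2C(=N[C@@](C)(c3ccc(Cl)cc3)[C@H]2c2ccc(Cl)cc2)S1`) gives 94 nM, compound 1 (`CC[C@@H]1CC[C@@H](C(=O)N2CCN(C)CC2)N1C(=O)C1=C(C(C)C)N2C(=N[C@@](C)(c3ccc(Cl)cc3)[C@H]2c2ccc(Cl)cc2)S1`) gives 83 nM and compound 2 (`CC[C@@H]1CC[C@@H](C(=O)N2CCN(C(C)=O)CC2)N1C(=O)C1=C(C(C)C)N2C(=N[C@@](C)(c3ccc(Cl)cc3)[C@H]2c2ccc(Cl)cc2)S1`) gives 130 nM. Compound 3 thus stands within the scatter of both others. Compound 4 (`CC[C@@H]1CC[C@@H](C(=O)N2CCN(C)[C@H](C)C2)N1C(=O)C1=C(C(C)C)N2C(=N[C@@](C)(c3ccc(Cl)cc3)[C@H]2c2ccc(Cl)cc2)S1`) has 3,4-dimethylpiperazin-1-yl in place of morpholin-4-yl on a carbonyl carbon. Related changes at this place gave a 1.1-fold higher number from compound 1 to compound 3 (0.05 log units; within the scatter), a 1.4-fold lower number from compound 2 to compound 3 (0.14 log units; within the scatter) and a 1.6-fold higher number from compound 1 to compound 2 (0.19 log units; within the scatter). For the measured compounds named here, no measured compound carries 3,4-dimethylpiperazin-1-yl, so its defined stereocentre remains untested. No change beyond the scatter is therefore expected in this assay. The expected size is a 1.1-fold lower number from compound 3 to compound 4 (0.04 log units; within the scatter). For compound 4, the estimate is 85 nM, with an expected range from 40 nM to 180 nM.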

Compound 4, concentration for 50% growth inhibition: 110 nM
The estimate for compound 4 lay 1.3-fold (0.11 log units) below the measured number; low and high end bracket the measured number.
By their numbers in this assay, from the lowest: compounds 1, 3, 4 and 2 (each within the scatter of the next).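

In this assay, 3,4-dimethylpiperazin-1-yl on the carbonyl carbon stays within the scatter of all three earlier groups, with a 1.2-fold higher number from compound 3 to compound 4 (0.07 log units; within the scatter) and a 1.2-fold lower number from compound 2 to compound 4 (0.07 log units; within the scatter). The closest comparison, a 1.3-fold higher number from compound 1 to compound 4 (0.12 log units; within the scatter), shows that one added methyl on a saturated ring carbon, with its defined stereocentre, brings no change beyond the scatter. Nothing measured here bears on why these numbers stay so close.

On these data alone, the opposite configuration at that stereocentre remains open. So does whether a ring without a second hetero atom, such as piperidine, or a group carrying a carboxylic acid would move the number beyond the scatter.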